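The source may hold more compounds than are shown below. What is called first, only, known or untested is meant among the compounds shown, and "the series" means these compounds.

Measured so far in an in vitro ADME assay on microsomes (Mus musculus) for metabolic stability; on this read-out higher numbers stand for a longer-lived compound and lower numbers for a shorter-lived compound:

- Compound 1 `CNC(=O)Nc1ccc(-c2nc(N3CC4CCC(C3)O4)c3cnn([C@H]4CC[C@@H](OC)CC4)c3n2)cc1` gives 0.283 h.
- For compound 2 `CNC(=O)Nc1ccc(-c2nc(N3CC4CCC(C3)O4)c3cnn([C@H]4CC[C@H](OC)CC4)c3n2)cc1` the assay reports only a limit, > 0.5 h.
- For compound 3 `CNC(=O)Nc1ccc(-c2nc(N3CC4CCC(C3)O4)c3cnn([C@H]4CC[C@H](O)CC4)c3n2)cc1` the assay likewise reports only a limit, > 0.5 h.

Compound 3 therefore stands at the ceiling of this assay rather than at a number, a position it shares with compound 2 (the limit of > 0.5 h in this assay, at which 2 of the 3 values shown sit). Against compound 1 the step is an at least 1.7-fold higher number from compound 1 to compound 3 (0.24 log units; that floor lies within the scatter), and against compound 2 the step is a step that the two limits leave unreadable from compound 2 to compound 3. Compound 4 `CNC(=O)Nc1ccc(-c2nc(N3CC4CCC(C3)O4)c3cnn(C)c3n2)cc1` differs from compound 3 in one place: methyl in place of 4-hydroxycyclohexyl on an aromatic nitrogen. The measured steps that touch this part of the molecule are an at least 1.7-fold higher number from compound 1 to compound 3 (0.24 log units; that floor lies within the scatter), where one substituent on the cyclohexyl ring replaced another, and a step that the two limits leave unreadable from compound 2 to compound 3, which the two limits leave unreadable. Neither of them removes the ring itself, so they set no clear direction for a change to methyl, and the expectation for compound 4 in this assay carries a wide range. Compound 4 is estimated at 0.4 h, from 0.15 h to 1.2 h, which means an expected step of an at least 1.2-fold lower number from compound 3 to compound 4 (0.09 log units; that floor lies within the scatter).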

Compound 4, half-life: > 0.5 h
Compound 4 was reported as a limit (the forecaster's own chance of this, stated with the estimate: 40%); middle value at least 1.2-fold (0.09 log units) away from the limit.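

In this assay, putting methyl in place of 4-hydroxycyclohexyl on the aromatic nitrogen removes the whole ring and its 2 defined stereocentres, yet compound 4 is still reported only as a limit, so this ring is not required for a compound to reach that ceiling. For the compounds shown here, measured against compound 1, which carries 4-methoxycyclohexyl at the same place and is the only compound with an exact number, the change to methyl gives an at least 1.7-fold higher number from compound 1 to compound 4 (0.24 log units; that floor lies within the scatter). The steps from compound 2 and compound 3 to compound 4 cannot be read, and the results now gather at one ceiling: the limit of > 0.5 h in this assay, at which 3 of the 4 values shown sit.

As far as these compounds go, how far compound 2, compound 3 and compound 4 each lie beyond that limit stays open, so the methyl and the two substituted cyclohexyl groups cannot be put in any order. Also open is what an ethyl chain, a cyclopropyl ring or a piperidine ring would do on the same nitrogen, since methyl and the cyclohexyl groups are the only substituents shown there.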